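The source may hold more compounds than are shown below. What is called first, only, known or untested is meant among the compounds shown, and "the series" means these compounds.

Of the compounds shown here, three have so far been tested in a functional assay on BGC-823 cells (Homo sapiens) for cytotoxicity, read by MTT assay; a higher number here means a weaker inhibitor, a lower number a stronger inhibitor: compound 1 `C/C1=C/C2=C(CC(C)(C)[C@@H]2O)[C@H](C)CC[C@@H]1O`, compound 2 `C/C1=C/[C@]23O[C@]2(CC(C)(C)C3=O)[C@H](C)CC[C@@H]1O` and compound 3 `C/C1=C/C2=CC(C)(C)C[C@@]2(OO)[C@H](C)CC[C@@H]1O`. Compound 1 gives > 10 ug/mL, which is a limit of the assay and not a number. Compound 2 gives > 10 ug/mL, again a limit. Compound 3 gives > 10 ug/mL, also a limit, so no number fixes where it stands. For the measured compounds named here, the whole series so far comes down to the limit of > 10 ug/mL in this assay, at which 3 of the 3 values shown sit.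

The next compound is compound 4 `C/C1=C/C2=CC(C)(C)C[C@]2(OO)[C@H](C)CC[C@@H]1O`, and it departs from compound 3 in one respect: the two compounds have the same atoms and bonds and differ only in configuration as drawn: 1 of 4 stereo elements differ; a stereocentre at a saturated ring carbon is drawn R in compound 3 and S in compound 4. Going by the values given here, no measured step in this assay shows what such a change does, so no shift beyond the scatter is expected, in either direction. The expected change, a step that the limit leaves unreadable from compound 3 to compound 4, is only an estimate. It rests on compound 3, whose reading of > 10 ug/mL is a limit. For compound 4 the estimated value is 14 ug/mL, with an expected range from 5 ug/mL to 30 ug/mL.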

Compound 4, half-maximal inhibitory concentration: > 10 ug/mL
Compound 4: a limit, no number; the forecaster's own chance of this, stated with the estimate: 70%; the middle value is on the limit's open side.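

For the compounds shown here, compound 3 and compound 4 each give only a limit, so no step between them can be read in this assay. The compounds shown leave open whether the configuration at that saturated ring carbon affects cytotoxicity at all, and what a measurable value for either compound would be.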